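Exchanging the Ring on the Urea Nitrogen of Compound 2

This account rests on a few compounds, and the source may have more. Where it says the series, first, only, none or still open, it means among the compounds named here.

Among the three compounds measured in a functional assay on cells (T-cell, Homo sapiens) for inhibition (a higher number here means a weaker inhibitor, a lower number a stronger inhibitor), compound 2 `COc1ccc(-c2cnc3nc(N)nc(N4CCN(C(=O)Nc5cccc(C)c5)CC4)c3n2)cc1OC` gives the lowest number: compound 2 gives 7 nM. Compound 1 `COc1ccc(-c2cnc3nc(N)nc(N4CCN(C(=O)c5ccccc5)CC4)c3n2)cc1OC` gives 400 nM in this assay, and compound 3 `CCOc1nc(N)nc2ncc(-c3ccc(C(F)(F)F)cc3)nc12`, built on a different core, gives 10000 nM. For the measured compounds named here, the only step that joins two measured compounds is a 57-fold lower number from compound 1 to compound 2 (1.76 log units; beyond the scatter), a large gain that comes with (3-methylphenyl)amino in place of phenyl on a carbonyl carbon.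

Compound 4 `COc1ccc(-c2cnc3nc(N)nc(N4CCN(C(=O)NCc5ccc(F)cc5)CC4)c3n2)cc1OC` keeps that carbamoyl link and differs from compound 2 only further out: 4-fluorobenzyl in place of 3-methylphenyl on an amide-type nitrogen. Read one bond further, the change is (3-methylphenyl)carbamoyl to (4-fluorobenzyl)carbamoyl. Going by the values given here, no measured step tests such an exchange of one aromatic piece for another on the amide-type nitrogen; the step from compound 1 to compound 2 concerns the link itself and is silent on the ring beyond it. The expectation for compound 4 is therefore a modest step, probably towards a somewhat higher number, and a 2.9-fold higher number from compound 2 to compound 4 (0.46 log units; beyond the scatter) is the size estimated. In this assay compound 4 is expected to give about 20 nM, with a range from 5 nM to 80 nM.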

Compound 4, half-maximal inhibitory concentration: 37 nM
Compound 4: middle estimate off by 1.9-fold (0.27 log units), on the low side, within the range that was stated.
By their numbers in this assay, from the lowest: compound 2; then compound 4; then compound 1; then compound 3.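

The ring on the amide-type nitrogen turns out to matter in this assay: a 5.3-fold higher number from compound 2 to compound 4 (0.72 log units; beyond the scatter), so this position does not accept 4-fluorobenzyl and 3-methylphenyl alike, although the step is modest beside the one that introduced the urea-type link. The gain over the phenyl on the carbonyl carbon also does not depend on 3-methylphenyl alone, since an 11-fold lower number from compound 1 to compound 4 (1.03 log units; beyond the scatter) is still a large step, and both compounds with an amino group on that carbonyl carbon give lower numbers than compound 1, with none of the compounds shown going against this. Nothing available explains why 4-fluorobenzyl gives the higher number of the two.

The exchange alters two things at once, replacing a phenyl with a benzyl and a methyl with a fluorine, so the compounds shown do not tell how much of the step belongs to each. An unsubstituted benzyl, a 4-fluorophenyl or a 3-methylbenzyl on the same nitrogen would separate the two, while a saturated ring such as cyclohexyl would ask whether an aromatic ring is needed there at all.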